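Chloro for methyl on a pair at the limit

This account rests on a few compounds, and the source may have more. Where it says the series, first, only, none or still open, it means among the compounds named here.

Compound 1 `Cc1cccc(-n2nncc2CN2C(=O)C3(C(C#N)=C(N)Oc4c3c3nc5ccccc5nc3c3ccccc43)c3ccccc32)c1` gives in a functional assay on HepG2 cells (Homo sapiens) for antiproliferative activity, read by MTT assay, with a stated time of 48 h (on this read-out higher numbers stand for weaker inhibition and lower numbers for stronger inhibition), a value that is only a limit of the assay, > 50000 nM. Compound 2 `Cc1ccc(C)c(-n2nncc2CN2C(=O)C3(C(C#N)=C(N)Oc4c3c3nc5ccccc5nc3c3ccccc43)c3ccccc32)c1` likewise gives only a limit in this assay, > 50000 nM.

The step from compound 1 to compound 2, a step that the two limits leave unreadable from compound 1 to compound 2, is unreadable. Compound 2 therefore stands at the limit, as the limit of > 50000 nM in this assay, at which 2 of the 2 values shown sit, shows. Compound 3 `Cc1ccc(Cl)cc1-n1nncc1CN1C(=O)C2(C(C#N)=C(N)Oc3c2c2nc4ccccc4nc2c2ccccc32)c2ccccc21` differs from compound 2 by chloro in place of methyl on an aromatic carbon. For the measured compounds named here, only the unreadable step bears on this change, so no step of readable size in this assay is expected. Compound 3 is estimated at 50000 nM, ranging from 15000 nM to 150000 nM. The expected step is a number no higher from compound 2 to compound 3 (the limit leaves the size open).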

Compound 3, half-maximal inhibitory concentration: > 50000 nM
Compound 3: no number, only a limit (the forecaster's own chance of this, stated with the estimate: 85%); the middle value sits exactly at the limit.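

In this assay, for the compounds shown here, compound 1, compound 2 and compound 3 each give only a limit of the assay, so no step among them can be read. From the compounds shown here alone, whether chloro in place of methyl changes inhibition at all stays open.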